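The source may hold more compounds than are shown below. What is called first, only, known or untested is meant among the compounds shown, and "the series" means these compounds.

Working notes on the series. In a functional assay on L5178Y cells (Mus musculus) for inhibition, read by MTT assay, with a stated time of 24 h (on this read-out lower numbers stand for stronger inhibition and higher numbers for weaker inhibition), compound 1 (`Oc1ccc([C@@H]2C/C(=N\Nc3ccccc3)c3c(O)cc(O)cc3O2)cc1`) gives only a limit, >= 11300 nM. Compound 2 (`Cn1cccc1/C=N/N=C1\C[C@@H](c2ccc(O)cc2)Oc2cc(O)cc(O)c21`) also gives only a limit, >= 11300 nM. Within the data shown here, the sole measured step, a step that the two limits leave unreadable from compound 1 to compound 2, therefore has no readable size, and what remains is the limit of >= 11300 nM in this assay, at which 2 of the 2 values shown sit. Compound 3 (`COc1cc(O)c2c(c1)O[C@H](c1ccc(O)cc1)C/C2=N\Nc1ccccc1`) differs from compound 1 by methyl in place of hydrogen on an oxygen on an aromatic ring. Among the measured compounds shown here, no measured step covers this change, so no step beyond the scatter is expected in this assay, and no direction is predicted. The expected step is a step that the limit leaves unreadable from compound 1 to compound 3. For compound 3 the estimate is 12000 nM, with an expected range of 5000 nM to 30000 nM.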

Compound 3, half-maximal inhibitory concentration: >= 11300 nM
Compound 3 was reported as a limit; the forecaster's own chance of this, stated with the estimate: 65%; the middle value does not contradict the limit.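

Compound 1 and compound 3 are both reported only as limits in this assay, so no step can be read between them. The compounds shown leave open how hydroxy to methoxy, or any other change, affects inhibition, and how strongly any of them inhibits: the limit of >= 11300 nM in this assay, at which 3 of the 3 values shown sit.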